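Replacing hydroxy with fluoro on a weakly cytotoxic compound

A few compounds are considered here, and "the series" means these few. Any claim that something is new, unique, unknown or untested is made for them only; others in the source may bear on it.

Measured so far in a functional assay on L1210 (1565) cells (Mus musculus) for cytotoxicity; on this read-out lower numbers stand for an effect already at smaller amounts and higher numbers for an effect only at larger amounts of compound:
Compound 1 `Oc1cc(-c2ccccc2)nc2ccc(Cl)cc12`: 0.5 ug/mL
Compound 2 `Oc1cc(-c2ccccc2)nc2c(O)cccc12`: > 10 ug/mL

Compound 2 stands at > 10 ug/mL in this assay, and this value is a limit of the assay, not a number. No effect size can therefore be given for it, only that bound. Compound 1 gives a true number, 0.5 ug/mL, so the shared core can carry a measurable effect.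

The next compound is compound 3 `Oc1cc(-c2ccccc2)nc2c(F)cccc12`. It differs from compound 2 in one place (fluoro in place of hydroxy on an aromatic carbon), with fluoro in place of hydroxy on an aromatic carbon, ortho to a fused ring and meta to a fused ring. For the measured compounds named here, no measured pair shows this exchange, so its size must be judged from the two values alone. A moderate shift towards smaller amounts in this assay is expected, probably beyond the usual scatter, though compound 3 may also stay at the limit. The expected change is an at least 3.3-fold lower number from compound 2 to compound 3 (0.52 log units; beyond the scatter). Compound 3 is estimated at 3 ug/mL, with an expected range from 0.8 ug/mL to 10 ug/mL.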

Compound 3, half-maximal effective concentration: 0.57 ug/mL
Estimate against measurement, compound 3: 5.3-fold (0.72 log units) above; measured number outside the range, below it.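

In this assay, the exchange at this aromatic carbon, ortho to a fused ring and meta to a fused ring, gives an at least 17-fold lower number from compound 2 to compound 3 (1.24 log units; beyond the scatter). With fluoro in place of hydroxy, compound 3 gives a true number, 0.57 ug/mL, so this position is now seen to be able to carry a measurable effect. The exchange of this single heavy atom is thus a large step, and its printed size is a bound rather than an exact figure, since one end of it is a limit of the assay and not a number: the limit of > 10 ug/mL in this assay, at which 1 of the 3 values shown sits.

Going by these compounds, what stays open is whether the step comes from the loss of hydroxy, from the arrival of fluoro, or from both, as these two groups alone cannot separate the two. On these data alone, a plain hydrogen, a methoxy group, a chloro group or an amine on this same carbon would show how far the effect belongs to fluoro itself, and whether fluoro acts in the same way elsewhere on the shared core also remains unknown.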